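Swapping a Phenol for a Pyridine on a Shared Core

A few compounds are considered here, and "the series" means these few. Any claim that something is new, unique, unknown or untested is made for them only; others in the source may bear on it.

Of the compounds shown here, two built on one shared core have been tested in an ADME assay on HeLa cells (Homo sapiens) for cytotoxicity, read by MTT assay; a higher number here means that more compound is tolerated, a lower number that less compound is tolerated. Within the data shown here, compound 1 `Cc1nc(-c2cccnc2)sc1-c1nnc(-c2ccc(Cl)cc2)o1` is the first of them. In this assay compound 1 gives only a limit, > 100 ug/mL. Compound 2 `Cc1nc(-c2cccnc2)sc1-c1nnc(-c2ccc(O)cc2)o1` differs from it by a single exchange, and in this assay compound 2 likewise gives only a limit, > 100 ug/mL. The step that the two limits leave unreadable from compound 1 to compound 2 therefore cannot be sized, because of the limit of > 100 ug/mL in this assay, at which 2 of the 2 values shown sit. Compound 3 `Cc1nc(-c2cccnc2)sc1-c1nnc(-c2ccncc2)o1` is not yet measured; it changes compound 2 by pyridin-4-yl in place of 4-hydroxyphenyl on an aromatic carbon. Among the measured compounds shown here, no measured step offers a readable size, so the expected step that the limit leaves unreadable from compound 2 to compound 3 is none beyond the scatter, and the most likely outcome is once more a limit rather than a number. Compound 3 is accordingly estimated at 150 ug/mL, within a range from 80 ug/mL to 300 ug/mL.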

Compound 3, half-maximal cytotoxic concentration: > 100 ug/mL
Compound 3: no number, only a limit; the forecaster's own chance of this, stated with the estimate: 80%; the middle value does not contradict the limit.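

Compound 3 also gives only a limit, so no step among compound 1, compound 2 and compound 3 can be read, because all three share the same limit: the limit of > 100 ug/mL in this assay, at which 3 of the 3 values shown sit.

From the compounds shown here alone, whether these three compounds differ at all in this assay remains open.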